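Benzhydryl ester series, cytotoxicity on A-375 cells

The compounds below may be only part of what the source reports. "The series", "measured", "known", "first", "only" and "open" are said of these compounds alone.

Measured so far:
compound 1 `CC1(C)[C@H](C(=O)OC(c2ccccc2)c2ccccc2)N2C(=O)/C(=C/C(=O)c3ccccc3)[C@H]2S1(=O)=O` — 17500 nM
compound 2 `CC1(C)[C@H](C(=O)OC(c2ccccc2)c2ccccc2)N2C(=O)/C(=C/C(=O)c3ccc([N+](=O)[O-])cc3)[C@H]2[S+]1[O-]` — 48200 nM
compound 3 `CC1(C)[C@H](C(=O)OC(c2ccccc2)c2ccccc2)N2C(=O)/C(=C/C(=O)c3ccc([N+](=O)[O-])cc3)[C@H]2S1(=O)=O` — 76700 nM

All three were run in a functional assay on A-375 cells (Homo sapiens) for cytotoxicity, read by MTT assay, with a stated time of 48 h; a lower number here means a stronger inhibitor, a higher number a weaker inhibitor. Compound 3 and compound 1 share a core and differ only at one aromatic position, (hydrogen in place of nitro on an aromatic carbon); that step is a 4.4-fold lower number from compound 3 to compound 1 (0.64 log units; beyond the scatter). Compound 2 and compound 3 carry the same (4-nitrophenyl)carbonyl arm on cores whose difference is not broken down here; their values lie within the usual scatter of each other.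

Compound 4 `CC1(C)[C@H](C(=O)OC(c2ccccc2)c2ccccc2)N2C(=O)/C(=C/C(=O)c3ccccc3)[C@H]2[S+]1[O-]` is not yet measured. It stands to compound 2 exactly as compound 1 stands to compound 3: the same change, (hydrogen in place of nitro on an aromatic carbon), at the same place. Because the measured step of a 4.4-fold lower number from compound 3 to compound 1 (0.64 log units; beyond the scatter) went in one direction, a step of similar size is expected here, a 3.7-fold lower number from compound 2 to compound 4 (0.57 log units; beyond the scatter). On that basis compound 4 is estimated at 13000 nM.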

Compound 4, half-maximal inhibitory concentration: 4500 nM
Compound 4: middle estimate off by 2.9-fold (0.46 log units), on the high side; the measured number lies below the stated range.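

In this assay, hydrogen in place of nitro on the aromatic carbon of the (4-nitrophenyl)carbonyl arm again gives a lower number on the other core, an 11-fold lower number from compound 2 to compound 4 (1.03 log units; beyond the scatter). The change therefore runs in the same direction on both cores, and the two steps do not differ by more than the scatter allows: the same change on two cores in this assay, a 4.4-fold lower number (0.64 log units; beyond the scatter) from compound 3 to compound 1 and an 11-fold lower number (1.03 log units; beyond the scatter) from compound 2 to compound 4, 2.4-fold (0.39 log units) apart, within the scatter of two such steps. For the compounds shown here, with only two pairs, this shows agreement on these two cores alone and does not show that the step would carry to any further core.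

The compounds shown leave open what an amine or a methoxy group would give at that aromatic carbon. They also leave open whether the step would persist with a carboxylic acid in place of the benzhydryl ester.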